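From a Limit Toward a Measurable Value

The compounds below may be only part of what the source reports. "The series", "measured", "known", "first", "only" and "open" are said of these compounds alone.

The values below come from a functional assay for inhibition, with Rattus norvegicus as the target; on this read-out higher numbers stand for weaker inhibition and lower numbers for stronger inhibition

Compound 1 `CC(C)(C)/N=c1\c(O)c(O)\c1=N/c1cccc2cnccc12` gives 1840 nM
Compound 2 `COc1ccc(Nc2c(NC(C)C(C)(C)C)c(=O)c2=O)cc1` gives 2400 nM
Compound 3 `CSc1ccc(Nc2c(NC(C)C(C)(C)C)c(=O)c2=O)cc1` gives > 30000 nM as a limit

Compound 3 sits at the limit of > 30000 nM in this assay, at which 1 of the 3 values shown sits, and therefore has a limit rather than a number. Compound 4 `COC(=O)c1ccc(Nc2c(NC(C)C(C)(C)C)c(=O)c2=O)cc1` has methoxycarbonyl in place of methylsulfanyl on an aromatic carbon, a change counted as methoxycarbonyl in place of methylsulfanyl on an aromatic carbon in full. Among the measured compounds shown here, the one measured step at this place is large, namely an at least 12-fold higher number from compound 2 to compound 3 (1.09 log units; beyond the scatter) for methylsulfanyl in place of methoxy. A sizeable move toward stronger inhibition is therefore expected in this assay, though one step is thin support. The expected step is an at least 5.0-fold lower number from compound 3 to compound 4 (0.69 log units; beyond the scatter) on this estimate. Compound 4 is estimated at 6000 nM, within an expected range from 1000 nM to 30000 nM overall.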

Compound 4, half-maximal inhibitory concentration: > 30000 nM
Compound 4: no number, only a limit; the forecaster's own chance of this, stated with the estimate: 25%; middle value at least 5.0-fold (0.69 log units) from the limit.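

Replacing methoxy with methoxycarbonyl on this aromatic carbon gives an at least 12-fold higher number from compound 2 to compound 4 (1.09 log units; beyond the scatter), so a second replacement group now gives a far higher number than methoxy. Of compound 2, compound 3 and compound 4, which differ only at this place, compound 2 alone gives a measurable value. The step between compound 3 and compound 4 cannot be read, because both stand at a limit: the limit of > 30000 nM in this assay, at which 2 of the 4 values shown sit.

Going by these compounds, how far compound 3 and compound 4 lie beyond that limit stays unknown. On these data alone, it also remains open whether a hydroxyl or an amine on this aromatic carbon would give a measurable value.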